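Swapping a dichlorophenyl for a nitrophenyl on a thiazole urea

The compounds below may be only part of what the source reports. "The series", "measured", "known", "first", "only" and "open" are said of these compounds alone.

Measured compounds:
- compound 1 `CN(C(=O)NC(=O)c1ccccc1F)c1nc(C(F)(F)F)c(C(=O)N/N=C/c2ccc(C(F)(F)F)cc2)s1`: 5.68 ug/mL
- compound 2 `CN(C(=O)NC(=O)c1ccc(Cl)c(Cl)c1)c1nc(C(F)(F)F)c(C(=O)N/N=C/c2ccc([N+](=O)[O-])cc2)s1`: 6.44 ug/mL
- compound 3 `CN(C(=O)NC(=O)c1cccc(C(F)(F)F)c1)c1nc(C(F)(F)F)c(C(=O)N/N=C/c2ccccc2C(F)(F)F)s1`: 12.1 ug/mL

These three compounds share a common core and were tested in a functional assay on A549 cells (Homo sapiens) for inhibition, read by MTT assay, with a stated time of 72 h; on this read-out higher numbers stand for weaker inhibition and lower numbers for stronger inhibition. Compound 1 gives 5.68 ug/mL, compound 2 gives 6.44 ug/mL and compound 3 gives 12.1 ug/mL. Compound 2 sits at the second highest number of the three. Its nearest neighbour is compound 1, whose number lies within the scatter of compound 2's; its furthest neighbour is compound 3, and that gap too falls within the scatter. On these numbers, then, the three compounds cannot be told apart in this assay.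

Compound 4 `CN(C(=O)NC(=O)c1ccc([N+](=O)[O-])cc1)c1nc(C(F)(F)F)c(C(=O)N/N=C/c2ccc([N+](=O)[O-])cc2)s1` has not yet been measured. It differs from compound 2 in one place: 4-nitrophenyl in place of 3,4-dichlorophenyl on a carbonyl carbon. Among the compounds with values here, no pair of measured compounds differing in exactly this way is available, so the step has to be judged from the spread of the three numbers alone. That spread is narrow, and nothing in it points in a particular direction. The step from compound 2 to compound 4 is therefore expected to be small, a 1.1-fold higher number from compound 2 to compound 4 (0.04 log units; within the scatter), and not beyond the scatter. Compound 4 is estimated to give 7 ug/mL in this assay, with a likely range from 3.5 ug/mL to 14 ug/mL.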

Compound 4, half-maximal inhibitory concentration: 8.98 ug/mL
Compound 4: middle estimate off by 1.3-fold (0.11 log units), on the low side; low and high end bracket the measured number.
By their numbers in this assay, from the lowest: compounds 1, 2, 4 and 3 (each within the scatter of the next, the first and the last beyond it).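

In this assay, within the data shown here, the pair of compound 2 and compound 4 gives the first direct reading at this position, the aromatic ring on a carbonyl carbon whose other neighbour is an amide-type nitrogen, and the change from 3,4-dichlorophenyl to 4-nitrophenyl reads as a 1.4-fold higher number from compound 2 to compound 4 (0.14 log units; within the scatter). The earlier compounds shown here differed from one another in more than one place at a time, so they could not isolate this position; this pair changes only the ring and its substituents, and on this step alone the two groups cannot be told apart. No measured property of either group accompanies this result, so the step comes with no explanation.

Going by these compounds, both groups at this position are substituted phenyl rings, so it remains open how the read-out would respond to a saturated ring such as morpholine, a simple amine, a carboxylic acid or a longer alkyl chain in their place. On these data alone, it is also open whether the same swap would read the same way if the 4-nitrophenyl at the far side of the shared core were replaced by another group.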